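Shortening a Side Chain in Seizure-Protection Screening

The source may hold more compounds than are shown below. What is called first, only, known or untested is meant among the compounds shown, and "the series" means these compounds.

Compound 1 `CCC(C(=O)N1CCN(c2cccc(F)c2)CC1)N1C(=O)CCC1=O`: 75%
Compound 2 `CC(C(=O)N1CCN(c2cccc(F)c2)CC1)N1C(=O)CCC1=O`: 100%
Compound 3 `CCC(C(=O)N1CCN(c2cccc(C(F)(F)F)c2)CC1)N1C(=O)CCC1=O`: 75%

These three compounds were tested in a functional assay on the whole organism (strain Swiss) with Mus musculus as the target, in the maximal electroshock model, with a stated time of 0.25 h, at a dose of 300 mg/kg by the intraperitoneal route; a lower number here means a weaker effect, a higher number a stronger effect of the compound at the dose given. Compound 2 differs from compound 1 by one change, (hydrogen in place of methyl on a saturated chain carbon, two bonds along the chain from an amide-type nitrogen in a ring and a carbonyl carbon), and that step raised the read-out a number 25 percentage points higher from compound 1 to compound 2 (beyond the scatter). Compound 3 differs from compound 1 only in its core, (trifluoromethyl in place of fluoro on an aromatic carbon), and this left the read-out unchanged no change at the digits printed from compound 1 to compound 3 (within the scatter).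

Compound 4 `CC(C(=O)N1CCN(c2cccc(C(F)(F)F)c2)CC1)N1C(=O)CCC1=O` has not yet been measured. It stands to compound 3 exactly as compound 2 stands to compound 1: the same change, (hydrogen in place of methyl on a saturated chain carbon, two bonds along the chain from an amide-type nitrogen in a ring and a carbonyl carbon), at the same place. Since that change earlier gave a modest rise a number 25 percentage points higher from compound 1 to compound 2 (beyond the scatter), a step of similar size is expected for compound 4, a number 20 percentage points higher from compound 3 to compound 4 (beyond the scatter), though the read-out cannot pass full protection. Compound 4 is therefore estimated at 95%, with a likely range from 75% to 100%.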

Compound 4, a percentage reported as activity, at one dose (the size of the read-out at that dose, not a potency): 75%
The estimate for compound 4 lay 20 percentage points above the measured number, and the stated range covers the measured number.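

In this assay, when ethyl was cut to methyl on the trifluoromethyl compounds, the read-out showed no change at the digits printed from compound 3 to compound 4 (within the scatter), so the rise seen with the fluoro compounds did not carry over to this core: the same change on two cores in this assay, a number 25 percentage points higher (beyond the scatter) from compound 1 to compound 2 and no change at the digits printed (within the scatter) from compound 3 to compound 4, 25 percentage points apart, beyond the scatter of two such steps

Swapping fluoro for trifluoromethyl also behaved differently with the shorter chain, giving a number 25 percentage points lower from compound 2 to compound 4 (beyond the scatter), although the same swap had not moved the ethyl compounds: the same change on two cores in this assay, no change at the digits printed (within the scatter) from compound 1 to compound 3 and a number 25 percentage points lower (beyond the scatter) from compound 2 to compound 4, 25 percentage points apart, beyond the scatter of two such steps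

So the two changes do not simply add up across these four compounds, but this does not explain why, does not measure potency at a single dose, and gives no rule for other cores.

Still open, on these data alone, is whether a longer chain, such as propyl, would follow the same pattern. As far as these compounds go, it is also open how chloro on that aromatic carbon would behave with each chain.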